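Removing one fluoro group from compound 2

The source may report more compounds than this note shows. Statements on the series, on what has been measured and on what is new or still open speak of the compounds shown alone.

In a functional assay on MDA-MB-231 cells (Homo sapiens) for inhibition, read by MTT assay, with a stated time of 72 h (a lower number here means a stronger inhibitor, a higher number a weaker inhibitor), compound 1 `COc1ccccc1-c1csc2cnc(Nc3ccc(NC(=O)[C@@H]4CCCNC4)cc3)nc12` gives 410 nM and compound 2 `COc1ccccc1-c1csc2cnc(Nc3cc(F)c(C(=O)NC4CCNCC4)cc3F)nc12` gives 2570 nM as the higher of the two numbers, a gap beyond the usual scatter. Among the compounds with values here, these two compounds differ in more than one place, so no measured step isolates a single change. Compound 3 `COc1ccccc1-c1csc2cnc(Nc3ccc(C(=O)NC4CCNCC4)cc3F)nc12` departs from compound 2 in one place only: hydrogen in place of fluoro on an aromatic carbon with hydrogen in place of fluoro on an aromatic carbon, ortho to a (piperidin-4-yl)carbamoyl group. Within the data shown here, the only pointer is compound 1 at 410 nM which carries no fluoro group at all, and it is a weak pointer given its other differences. In this assay a small move toward a lower number is therefore expected, not clearly beyond the scatter. The estimated step is a 1.7-fold lower number from compound 2 to compound 3 (0.23 log units; within the scatter) and it remains uncertain. For compound 3 the estimated value is 1500 nM with an expected range from 600 nM to 4000 nM in this measurement.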

Compound 3, half-maximal inhibitory concentration: 1610 nM
Beside the measured number, compound 3's estimate is 1.1-fold (0.03 log units) below it; the range from low to high includes it.
By their numbers in this assay, from the lowest: compound 1; then compounds 3 and 2 (each within the scatter of the next).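

In this assay, within the data shown here, hydrogen in place of fluoro on the aromatic carbon ortho to a (piperidin-4-yl)carbamoyl group gives a 1.6-fold lower number from compound 2 to compound 3 (0.20 log units; within the scatter) as the first step that isolates a single change. Because this step lies within the scatter, the data give no sign that the fluoro group at this position matters in this assay, and compound 2 and compound 3 cannot be told apart here. No measurement available here bears on the reason for this result.

As far as these compounds go, the fluoro group para to this position is present in both compounds, so its own contribution remains open. Also open, from the compounds shown here alone, is whether a chloro group or a nitrile at the position studied here would give a step beyond the scatter.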